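Swapping a phenethyl arm for a fluorophenyl ring

This account rests on a few compounds, and the source may have more. Where it says the series, first, only, none or still open, it means among the compounds named here.

Of the compounds shown here, three share a fused two-ring core and have been tested in a functional assay on FM3A cells (Mus musculus) for inhibition, read by cell counting, with a stated time of 2 days; a higher number here means a weaker inhibitor, a lower number a stronger inhibitor. Compound 1 `COc1cccc(-c2nn3cc(-c4cccc(N)c4)nc3s2)c1` gives 29000 nM, and compound 3 `COc1ccc(-c2csc3nc(-c4cccc(N)c4)cn23)cc1` gives 11000 nM. Compound 2 `C=C(Br)C(=O)Nc1cccc(-c2cn3nc(CCc4ccccc4)sc3n2)c1` gives 2600 nM, the lowest number of the three and therefore the strongest inhibitor among them, with its closest neighbour compound 3 and compound 1 further away, both beyond the usual scatter.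

Compound 4 `C=C(Br)C(=O)Nc1cccc(-c2cn3nc(-c4ccc(F)cc4)sc3n2)c1` has not yet been measured. It differs from compound 2 in one place: 4-fluorophenyl in place of phenethyl on an aromatic carbon. Going by the values given here, no pair of measured compounds shows this exact change, so nothing directly tells how the number will move. Compounds 1 and 3 carry an aromatic ring at a comparable position on the core, but they also differ elsewhere, so their weaker numbers cannot be pinned on the ring alone. The expectation is a small step, a 1.5-fold higher number from compound 2 to compound 4 (0.16 log units; within the scatter), toward a slightly weaker inhibitor, near the edge of the scatter. Compound 4 is estimated at 3800 nM, within a range from 1200 nM to 12000 nM.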

Compound 4, half-maximal inhibitory concentration: 610 nM
Compound 4: the middle estimate sits 6.2-fold (0.79 log units) above what was measured; measured number outside the range, below it.
By their numbers in this assay, from the lowest: compound 4; then compound 2; then compound 3; then compound 1.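

In this assay, putting 4-fluorophenyl in place of phenethyl gives a 4.3-fold lower number from compound 2 to compound 4 (0.63 log units; beyond the scatter), so this aromatic carbon of the core does respond to what it carries, and the stronger number belongs to the ring with the fluorine rather than the ring on a chain. By the counts, the two groups are much alike: each has one six-membered aromatic ring, no hydrogen-bond donors or acceptors and no net charge, so those counts do not separate them. Nothing measured here explains the gain.

The step removes the chain and adds the fluorine together, so their separate shares cannot be told apart, and an unsubstituted phenyl ring would be needed to divide them. On these data alone, how an amine or a longer chain would fare at this position also remains open.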